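The source may report more compounds than this note shows. Statements on the series, on what has been measured and on what is new or still open speak of the compounds shown alone.

Measured compounds:
Compound 1 `Cc1cc(O)c(C2=NN(c3ccc(S(N)(=O)=O)cc3)C(/C=C/c3ccccc3)C2)cc1Cl`: 38300 nM
Compound 2 `COc1ccc(C2CC(c3cc(Cl)c(C)cc3O)=NN2c2ccc(S(N)(=O)=O)cc2)cc1OC`: 27800 nM

Both numbers come from a functional assay on OVCAR-5 cells (Homo sapiens) for antiproliferative activity, with a stated time of 48 h; on this read-out higher numbers stand for lower toxicity in this test and lower numbers for higher toxicity in this test. Compound 1 has the highest of the two numbers, yet the step of a 1.4-fold lower number from compound 1 to compound 2 (0.14 log units; within the scatter) stays within the ordinary scatter of this test, so the two values cannot be ranked against each other. Compound 3 `COc1ccc(C2CC(c3cc(Cl)c(C)cc3O)=NN2c2ccc(S(N)(=O)=O)cc2)c(OC)c1OC` has not yet been measured. It differs from compound 1 by 2,3,4-trimethoxyphenyl in place of 2-phenylethenyl on a saturated ring carbon. For the measured compounds named here, the one measured step that bears on this change is a 1.4-fold lower number from compound 1 to compound 2 (0.14 log units; within the scatter), in which a dimethoxyphenyl ring took the same place on the saturated ring carbon and the number barely moved. A trimethoxyphenyl ring is a closely related change, so the expected step is a 1.4-fold lower number from compound 1 to compound 3 (0.14 log units; within the scatter), nothing beyond the scatter in either direction. For compound 3 in this assay the estimated value is 28000 nM, with a range from 12000 nM to 65000 nM.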

Compound 3, concentration lethal to 50% of the cells: 9790 nM
Estimate against measurement, compound 3: 2.9-fold (0.46 log units) above, and the stated range ends above it.
By their numbers in this assay, from the lowest: compound 3; then compounds 2 and 1 (each within the scatter of the next).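

At this position on the saturated ring carbon, the choice of group can shift the number in this assay beyond the scatter, as 2,3,4-trimethoxyphenyl gives a 3.9-fold lower number from compound 1 to compound 3 (0.59 log units; beyond the scatter) and so means higher toxicity in this test. A single added methoxy on the aromatic ring also matters, with a 2.8-fold lower number from compound 2 to compound 3 (0.45 log units; beyond the scatter), even though the earlier dimethoxyphenyl change stayed within the scatter. No measurement shown here explains why the number falls.

The compounds shown leave open whether this shift depends on where the added methoxy sits on the ring or simply on its presence. They also leave open whether another group in its place, such as an ethoxy group or an amine, would move the number as far.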